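A few compounds are considered here, and "the series" means these few. Any claim that something is new, unique, unknown or untested is made for them only; others in the source may bear on it.

Working notes on the series.

Compound 1 `Cc1c(C#N)c(-c2ccccc2)nn1CCCN1CCN(c2ccc(F)cc2)CC1` is the reference point: in a functional assay on the whole organism (Abdomen, strain Swiss) for inhibition, with Mus musculus as the target, with stated times of 30 min, 10 min and 5 min, at a dose of 40 mg/kg by the oral route (a lower number here means a weaker effect, a higher number a stronger effect of the compound at the dose given), compound 1 gives 51%. Compound 2 `O=c1occ(-c2ccccc2)n1CCCN1CCN(c2ccc(F)cc2)CC1` shares the piperazine-linked 4-fluorophenyl arm but carries a different core; in this assay compound 2 gives 34%. Compound 2 thus stands as the lower of the two measured compounds, and the gap to compound 1 lies beyond the usual scatter of this read-out.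

Compound 3 `O=c1occ(-c2ccccc2)n1CCCN1CCN(c2cccc(Cl)c2)CC1` has not been measured. Relative to compound 2 the change is 3-chlorophenyl in place of 4-fluorophenyl on an amine nitrogen in a ring, the core being kept. Going by the values given here, no measured pair in the set isolates this change, so nothing in the data fixes its direction. The step is therefore expected to be small, no change at the digits printed from compound 2 to compound 3 (within the scatter), and not beyond the scatter in either direction. For compound 3 the estimated inhibition in this assay is 34%, with a range from 15% to 55%.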

Compound 3, a percentage reported as inhibition, in the whole organism at one dose (the size of the read-out at that dose, not a potency): 38%
Compound 3: the middle estimate sits 4 percentage points below what was measured; the range from low to high includes it.
By their numbers in this assay, from the lowest: compounds 2 and 3 (each within the scatter of the next); then compound 1.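

Going by these compounds alone, the first pair that differs in one place shows that, in this assay, 3-chlorophenyl in place of 4-fluorophenyl on an amine nitrogen in a ring gives a number 4 percentage points higher from compound 2 to compound 3 (within the scatter). With the core kept, this read-out at the single oral dose therefore does not separate the two aryl groups, and the exchange leaves compound 3 within the scatter of compound 2. Nothing available explains this outcome or assigns a role to either halogen-bearing ring.

Going by these compounds, it remains open whether an unsubstituted phenyl, a benzyl or a longer chain between the core and the ring nitrogen would give a step beyond the scatter. On these data alone, it is also open whether the same exchange on the core of compound 1 would stay as small, and the single dose gives no measure of potency for either group.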